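The compounds below may be only part of what the source reports. "The series", "measured", "known", "first", "only" and "open" are said of these compounds alone.

Compound 1 `Cn1c(-c2ccccc2C(F)(F)F)nnc1C12CCC(CCS(=O)(=O)C(C)(C)C)(CC1)CC2` is tested in an assay on CHO-K1 cells for inhibition of 11-beta-hydroxysteroid dehydrogenase type 2 (Mus musculus), read by scintillation proximity assay (a higher number here means a weaker inhibitor, a lower number a stronger inhibitor), and gives > 4000 nM, which is a limit of the assay rather than a number. Compound 2 `CCS(=O)(=O)CCC12CCC(c3nnc(-c4ccccc4C)n3C)(CC1)CC2` in this assay likewise gives > 4000 nM, again a limit and not a number. Among the measured compounds shown here, both values sit at the limit of > 4000 nM in this assay, at which 2 of the 2 values shown sit, so no measured step between them can be read. Compound 3 `CCS(=O)(=O)CCC12CCC(c3nnc(-c4ccccc4Br)n3C)(CC1)CC2` differs from compound 2 by bromo in place of methyl on an aromatic carbon. With only limits as guidance, the change is expected to give a step that the limit leaves unreadable from compound 2 to compound 3, likely none beyond the scatter. Compound 3 is therefore estimated at 6000 nM, within 1500 nM to 30000 nM.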

Compound 3, half-maximal inhibitory concentration: > 4000 nM
Compound 3: a limit, no number; the forecaster's own chance of this, stated with the estimate: 75%; the middle value is on the limit's open side.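

Among the compounds shown here, compound 3, like compound 2, gives only a limit and not a number, so no step between compound 2 and compound 3 can be read: the limit of > 4000 nM in this assay, at which 3 of the 3 values shown sit. Left open is which change to these compounds, if any, would give a real number in this assay.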